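The source may hold more compounds than are shown below. What is called first, only, known or untested is meant among the compounds shown, and "the series" means these compounds.

Compound 1 `Cc1ccc(S(=O)(=O)Nc2cccc([N+](=O)[O-])c2)cc1` and compound 2 `O=[N+]([O-])c1cccc(NS(=O)(=O)c2ccc(Cl)cc2)c1` share one core, while compound 3 `Cc1ccc(S(=O)(=O)Nc2ccc(F)cc2)cc1` and compound 4 `O=S(=O)(Nc1ccc(F)cc1)c1ccc(Cl)cc1` share another; the difference between the two cores is not broken down here. In a physicochemical assay for acid dissociation, compound 1 gives 8.27 and compound 2 gives 7.51, so the change chloro in place of methyl on an aromatic carbon produced a number 0.76 log units lower from compound 1 to compound 2 (beyond the scatter). Compound 3 gives 9.2 in this assay, the highest of the three numbers. Compound 4 carries the same change, (chloro in place of methyl on an aromatic carbon), on the other core. Within the data shown here, since the only measured example of this change, from compound 1 to compound 2, gave a number 0.76 log units lower from compound 1 to compound 2 (beyond the scatter), a step of a number 0.75 log units lower from compound 3 to compound 4 (beyond the scatter) is expected here as well. Compound 4 is therefore estimated at 8.45 in this assay, within a range from 8.1 to 8.8.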

Compound 4, acid dissociation constant: 8.41
Estimate against measurement, compound 4: 0.04 log units above, within the range that was stated.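

In this assay, chloro in place of methyl on an aromatic carbon gave a number 0.79 log units lower from compound 3 to compound 4 (beyond the scatter), and the same change on the other core gave a number 0.76 log units lower from compound 1 to compound 2 (beyond the scatter), so the two steps are of much the same size. This shows that the change carried over between these two cores, but two cores are too few to show that it would carry over to every core in this series. Nothing available here explains the size of either step.

The compounds shown only swap methyl for chloro, so it remains open how a methoxy, a trifluoromethyl or an amine in that place would shift the number. From the compounds shown here alone, it also remains open whether the step would hold on a core carrying a carboxylic acid.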